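Pentyloxy in place of methoxy: compound 4 expected

The compounds below may be only part of what the source reports. "The series", "measured", "known", "first", "only" and "open" are said of these compounds alone.

Measured compounds:
compound 1, `CCCCCOC1(c2ccc(Cl)cc2)SC=C(C)n2c1noc2=O`: > 100000 nM
compound 2, `COC1(c2ccc(Br)cc2)SC=C(C)n2c1noc2=O`: 148000 nM
compound 3, `CC1=CSC(O)(c2ccccc2)c2noc(=O)n21`: > 100000 nM

Three compounds sharing one core were tested in a functional assay on A2780 cells (Homo sapiens) for antiproliferative activity, read by MTT assay, with a stated time of 3 days; a lower number here means a stronger inhibitor, a higher number a weaker inhibitor. For the measured compounds named here, compound 2 is the only one with a number; in this assay compound 2 gives 148000 nM. For compound 1 the result is a limit of the assay, > 100000 nM. For compound 3 the result is likewise a limit, > 100000 nM. So compound 2 stands as the one measurable value, and the limit of > 100000 nM in this assay, at which 2 of the 3 values shown sit, marks where the other two sit.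

Compound 4, `CCCCCOC1(c2ccc(Br)cc2)SC=C(C)n2c1noc2=O`, is not yet measured. It differs from compound 2 by butyl in place of hydrogen on a saturated chain carbon bound to an oxygen on a saturated carbon. Going by the values given here, no measured pair here shows what such a step does, so its size is not known from these data. Compound 1 also bears a pentyloxy group and sits at the limit of > 100000 nM in this assay, at which 2 of the 3 values shown sit. On that basis the step from compound 2 to compound 4 is expected to be a 1.1-fold higher number from compound 2 to compound 4 (0.03 log units; within the scatter), nothing beyond the scatter, with a real chance of another limit. For compound 4 the expected value in this assay is 160000 nM, within 60000 nM to 450000 nM.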

Compound 4, half-maximal inhibitory concentration: 108000 nM
For compound 4 the middle estimate is 1.5-fold (0.17 log units) above the measured one, within the range that was stated.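

In this assay, for the compounds shown here, the change from methoxy to pentyloxy gives the first readable step at this place, on a saturated chain carbon bound to an oxygen on a saturated carbon: a 1.4-fold lower number from compound 2 to compound 4 (0.14 log units; within the scatter). Butyl in place of hydrogen there therefore makes no difference that can be told from the scatter. Compound 1, which also bears pentyloxy, remains a limit of the assay at > 100000 nM, so the step from it to compound 4, bromo in place of chloro, cannot be read, and the limit stays common in the set: the limit of > 100000 nM in this assay, at which 2 of the 4 values shown sit.

The compounds shown leave open whether an amine, a carboxylic acid or a chain longer than pentyl at this place would move the number beyond the scatter. They also leave open how bromo and chloro compare when both compounds give a number.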